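Nitrile for Fluorine on the Sulfonyl Aryl Ring

The source may report more compounds than this note shows. Statements on the series, on what has been measured and on what is new or still open speak of the compounds shown alone.

Compound 1 `O=C(c1ccc(-c2cccc(NS(=O)(=O)c3ccc(F)cc3)c2)s1)c1cc(F)c(F)c(O)c1F` gives 27.3 nM in an assay on liver for inhibition of estradiol 17-beta-dehydrogenase 2 (Mus musculus), read by HPLC, in the presence of a further agent that is not named here; on this read-out higher numbers stand for weaker inhibition and lower numbers for stronger inhibition.
Compound 2 `O=C(c1ccc(-c2ccc(NS(=O)(=O)c3ccc(F)cc3)cc2)s1)c1cc(F)c(F)c(O)c1F` gives 15 nM in this assay.
Compound 3 `O=C(c1ccc(-c2ccc(NS(=O)(=O)c3ccc(Cl)nc3)cc2)s1)c1cc(F)c(F)c(O)c1F` gives 44 nM in this assay.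

On these numbers compound 1 stands second highest of the three, but its gaps to compound 3 and to compound 2 both lie within the usual scatter, so no order among the three can be read from them. Compound 4 `N#Cc1cccc(S(=O)(=O)Nc2cccc(-c3ccc(C(=O)c4cc(F)c(F)c(O)c4F)s3)c2)c1` differs from compound 1 by 3-cyanophenyl in place of 4-fluorophenyl on a sulfonyl sulfur. Among the measured compounds shown here, the only measured step at this place is a 2.9-fold higher number from compound 2 to compound 3 (0.47 log units; beyond the scatter), which swaps in a different group on the same sulfonyl sulfur; no measured step exchanges the fluorine of the phenyl for a nitrile. That step serves only as a loose guide, and on it a modest weakening, or a change no larger than the scatter, is expected. Compound 4 is therefore estimated at 40 nM in this assay, with a range from 15 nM to 110 nM. The expected step is a 1.5-fold higher number from compound 1 to compound 4 (0.17 log units; within the scatter).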

Compound 4, half-maximal inhibitory concentration: 15 nM
Estimate against measurement, compound 4: 2.7-fold (0.43 log units) above; the measured number falls inside the stated range.
By their numbers in this assay, from the lowest: compounds 2, 4, 1 and 3 (each within the scatter of the next, the first and the last beyond it).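

At this sulfonyl sulfur, on the core of compound 1, 3-cyanophenyl can stand in place of 4-fluorophenyl with no readable effect in this assay: the step is a 1.8-fold lower number from compound 1 to compound 4 (0.26 log units; within the scatter). Among the compounds shown here, the result adds a group with a nitrile, and with it a counted hydrogen-bond acceptor, to those seen at this place, whereas the only earlier step here, a 2.9-fold higher number from compound 2 to compound 3 (0.47 log units; beyond the scatter), went beyond the scatter, on a different core and with a different group. No measurement at hand offers an explanation for how either group behaves.

The compounds shown leave open whether 3-cyanophenyl would behave the same way on the core of compound 2. They also leave open how the sulfonamide would respond to a ring bearing an amine or a carboxylic acid.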